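The source may report more compounds than this note shows. Statements on the series, on what has been measured and on what is new or still open speak of the compounds shown alone.

Compounds measured in an assay for inhibition of serine/threonine-protein kinase PLK2 (Homo sapiens), read by FRET and Z'-LYTE, with a stated time of 1 h; a higher number here means a weaker inhibitor, a lower number a stronger inhibitor:

Compound 1, `CCC1C(=O)N(C)c2cnc(-n3ccc4cc(C(=O)NC)ccc43)nc2N1c1ccn(C)n1`, 218 nM
Compound 2, `CCCCNS(=O)(=O)c1ccc(Nc2ncc3c(n2)N(c2ccn(C)n2)C(CC)C(=O)N3C)cc1`, 191 nM
Compound 3, `CC[C@@H]1C(=O)N(C)c2cnc(-n3ccc4cc(C(=O)NCC(C)C)ccc43)nc2N1C1CCCC1`, 18.6 nM

Compound 3 has the lowest of the three numbers. Compound 2 lies higher, and compound 1 a little further still; both gaps lie beyond the usual scatter, so compound 3 is the strongest inhibitor of the three in this assay. Compound 1 and compound 2 are within the scatter of each other, and nothing is said here about an order between them.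

The next compound, compound 4, is `CC[C@@H]1C(=O)N(C)c2cnc(-n3ccc4cc(C(N)=O)ccc43)nc2N1C1CCCC1`. It differs from compound 3 in one place: hydrogen in place of isobutyl on an amide-type nitrogen. Among the compounds with values here, no single-change step between measured compounds is available, and compound 3 is the only compound with this cyclopentyl-bearing core, so the effect of shortening the amide substituent has to be guessed. A modest loss is expected, a step upward in this assay, though it could still fall within the scatter.

Compound 4 is therefore estimated at 45 nM, with a range from 15 nM to 150 nM. The step expected from compound 3 to compound 4 is a 2.4-fold higher number from compound 3 to compound 4 (0.38 log units; beyond the scatter).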

Compound 4, half-maximal inhibitory concentration: 28.5 nM
Compound 4: middle estimate off by 1.6-fold (0.20 log units), on the high side; the range from low to high includes it.
By their numbers in this assay, from the lowest: compounds 3 and 4 (each within the scatter of the next); then compounds 2 and 1 (each within the scatter of the next).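

In this assay, within the data shown here, replacing the isobutyl on the amide-type nitrogen with hydrogen gives a 1.5-fold higher number from compound 3 to compound 4 (0.19 log units; within the scatter), the first single-change step in this set, and it does not separate the two compounds. At this position, on the amide-type nitrogen whose other neighbour is the carbonyl carbon, the four carbon atoms of the isobutyl can be removed without a change that this measurement can distinguish, so the carbamoyl of compound 4 and the isobutylcarbamoyl of compound 3 cannot be told apart here. Nothing available explains this result.

The compounds shown leave open whether other groups on this nitrogen, such as a longer chain or a chain ending in an amine or a carboxylic acid, would also stay within the scatter of compound 4 in this assay. From the compounds shown here alone, this single step also comes from compounds carrying cyclopentyl, so it remains unknown whether the same change would have as little effect on a core bearing a different group at that site.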